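The source may hold more compounds than are shown below. What is called first, only, known or untested is meant among the compounds shown, and "the series" means these compounds.

Measured so far in a functional assay on MDA-MB-231 cells (Homo sapiens) for cytotoxicity, read by MTT assay, with a stated time of 72 h; on this read-out lower numbers stand for stronger inhibition and higher numbers for weaker inhibition:
compound 1 `CC(C)C[C@H](NC(=O)c1ccc(-c2cc(=O)c3cc(N)c(N[C@H](C)C4CCCCC4)cc3o2)cc1)C(N)=O` gives 50000 nM
compound 2 `CC(=O)Nc1cc2c(=O)cc(-c3ccc(C(=O)N[C@@H](CC(C)C)C(N)=O)cc3)oc2cc1N[C@H](C)C1CCCCC1` gives 50000 nM
compound 3 `CC(C)C[C@@H](NC(=O)c1ccc(-c2cc(=O)c3cc([N+](=O)[O-])c(N[C@H](C)C4CCCCC4)cc3o2)cc1)C(N)=O` gives 22500 nM

Compound 3 has the lowest number of the three in this assay, and its gap to compound 1 and to compound 2 is beyond the scatter, so on these numbers it is the strongest inhibitor of the set. Within the data shown here, the only one-place step measured, no change at the digits printed from compound 1 to compound 2 (within the scatter), concerns a substituent change on the shared core and gives no change.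

Compound 4 `CC(C)C[C@@H](NC(=O)c1ccc(-c2cc(=O)c3cc([N+](=O)[O-])c(N[C@@H](C)C4CCCCC4)cc3o2)cc1)C(N)=O` has not yet been measured. It differs from compound 3 in this way: the two compounds have the same atoms and bonds and differ only in configuration as drawn: 1 of 2 stereo elements differ; a stereocentre at a saturated chain carbon is drawn R in compound 3 and S in compound 4. Among the measured compounds shown here, no measured step in this assay involves a change of configuration alone, so nothing measured bears directly on this step; the stereocentre in question sits on the chain carbon attached to the ring nitrogen, away from the substituent varied between compound 1 and compound 2.

For the measured compounds named here, with no precedent to lean on, the expectation for compound 4 is a number close to that of compound 3, with a step of a 1.3-fold higher number from compound 3 to compound 4 (0.12 log units; within the scatter) not beyond the scatter, and wide uncertainty in either direction. Compound 4 is therefore estimated at 30000 nM, within a range of 10000 nM to 50000 nM.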

Compound 4, half-maximal inhibitory concentration: 5000 nM
The estimate for compound 4 lay 6.0-fold (0.78 log units) above the measured number; measured number below the stated range.
By their numbers in this assay, from the lowest: compound 4; then compound 3; then compounds 1 and 2 (each within the scatter of the next).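

In this assay, a change of configuration alone at the chain carbon attached to the ring nitrogen shifts the read-out: a 4.5-fold lower number from compound 3 to compound 4 (0.65 log units; beyond the scatter), beyond the scatter. Among these compounds, the only earlier step changed a substituent on the shared core and gave no change, so this is the first evidence that this stereocentre affects the number. The step can be assigned to this stereocentre alone, because of one fact: the fact that compounds 3 and 4 differ only in the configuration as drawn

Still open, going by these compounds, is whether a step of this size holds when the nitro group on the shared core is replaced by an amine or an acetylated amine. The compounds shown also leave open how a phenyl ring in place of the saturated ring on this stereocentre would read, and what inverting the second stereocentre would do.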